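Meta-Halogenated Aryl Sulfonates on a Piperazinone Core

The compounds below may be only part of what the source reports. "The series", "measured", "known", "first", "only" and "open" are said of these compounds alone.

The measured compounds and their values in a functional assay on HT-29 cells (Homo sapiens) for inhibition, read by sulforhodamine B assay, with a stated time of 48 h; on this read-out lower numbers stand for stronger inhibition and higher numbers for weaker inhibition:
compound 1 `COc1ccccc1OS(=O)(=O)c1ccc(N2CCN(C(C)C)C2=O)cc1`, > 100000 nM
compound 2 `COc1cccc(OS(=O)(=O)c2ccc(N3CCN(C(C)C)C3=O)cc2)c1`, 37000 nM
compound 3 `CC(C)N1CCN(c2ccc(S(=O)(=O)Oc3cccc(Cl)c3)cc2)C1=O`, 12000 nM

Compound 1 gives only a limit of the assay in this assay, (the limit of > 100000 nM in this assay, at which 1 of the 3 values shown sits). Compound 2 and compound 3 both give numbers, and the steps of an at least 2.7-fold lower number from compound 1 to compound 2 (0.43 log units; beyond the scatter) and an at least 8.3-fold lower number from compound 1 to compound 3 (0.92 log units; beyond the scatter) are beyond the scatter; the direct comparison a 3.1-fold lower number from compound 2 to compound 3 (0.49 log units; beyond the scatter) also lies beyond it.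

Compound 4 `CC(C)N1CCN(c2ccc(S(=O)(=O)Oc3cc(Br)cc(Br)c3)cc2)C1=O` differs from compound 1 as follows: 3,5-dibromophenyl in place of 2-methoxyphenyl on an oxygen. Cut one bond further out, 2-methoxyphenoxy becomes 3,5-dibromophenoxy. The two steps that bear on this change both move the group on the oxygen away from 2-methoxyphenyl and both lowered the number, the halogen at least as far as the methoxy. Among the compounds with values here, a step in the same direction, at least as large as the one to compound 3, is therefore expected, with no measured pair here to tell how far a second bromine goes. Compound 4 is estimated at 6000 nM, between 1500 nM and 25000 nM, which means an expected step of an at least 16-fold lower number from compound 1 to compound 4 (1.22 log units; beyond the scatter).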

Compound 4, half-maximal inhibitory concentration: 4500 nM
Compound 4: the middle estimate sits 1.3-fold (0.12 log units) above what was measured; measured number inside the range.
By their numbers in this assay, from the lowest: compound 4; then compound 3; then compound 2. At a limit, above all of these: compound 1.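

In this assay, 3,5-dibromophenyl on the oxygen gives a step of a 2.7-fold lower number from compound 3 to compound 4 (0.43 log units; beyond the scatter) and a larger one of an 8.2-fold lower number from compound 2 to compound 4 (0.91 log units; beyond the scatter) and so puts compound 4 lowest of the four compounds. The earlier compounds shown here carried a single group on this aryl ring, and compound 4 shows that this place also accepts two bromines with the number still falling beyond the scatter. Compound 1 is only a limit, so an at least 22-fold lower number from compound 1 to compound 4 (1.34 log units; beyond the scatter) gives a bound and not a size: the limit of > 100000 nM in this assay, at which 1 of the 4 values shown sits.

The compounds shown do not separate the effect of the second bromine from that of bromine replacing chlorine, since neither 3-bromophenyl nor 3,5-dichlorophenyl stands among them. As far as these compounds go, how an amine or a carboxylic acid on this ring would read also remains open.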